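Swapping a fused ring's atoms: what stays of the compound?

The source may hold more compounds than are shown below. What is called first, only, known or untested is meant among the compounds shown, and "the series" means these compounds.

Measured compounds in an ADME assay on microsomes from liver (Mus musculus) for metabolic stability, read by LC-MS, with a stated time of 30 min, tested at 1 uM; on this read-out lower numbers stand for a less stable compound and higher numbers for a more stable compound:
compound 1 `O=C(NCc1ccc(S(=O)(=O)N2CCCCC2)cc1)c1cc2cnccc2s1`: "below limit of detection" (no number reported)
compound 2 `O=C(NCc1ccc(S(=O)(=O)c2ccccc2)cc1)c1ccc2ccncc2c1`: 3.3%
compound 3 `O=C(NCc1ccc(S(=O)(=O)c2cccc(C(F)(F)F)c2)cc1)c1cnc2nccn2c1`: 27%

Compound 1 stands apart from the others: in this assay it gives only "below limit of detection" (no number reported), so no number stands for it. Compound 2 gives 3.3% in this assay, and compound 3 gives 27%; these two values show compound 3 with more compound remaining than compound 2. Compound 4 `O=C(NCc1ccc(S(=O)(=O)N2CCCCC2)cc1)c1cc2cccnc2s1` has not yet been measured. It differs from compound 1 in one place: a group of 9 heavy atoms (7 carbon, 1 nitrogen, 1 sulfur; one five-membered aromatic ring with 1 hetero atom, one six-membered aromatic ring with 1 hetero atom) in place of a group of 9 heavy atoms (7 carbon, 1 nitrogen, 1 sulfur; one five-membered aromatic ring with 1 hetero atom, one six-membered aromatic ring with 1 hetero atom), on a carbonyl carbon. Within the data shown here, since compound 1 gives no number, no step can be computed, and the expectation for compound 4 rests on compound 1 alone. Compound 4 is expected to give a low value in this assay, estimated at 5%, within a range of 0% to 20%.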

Compound 4, percent of the compound remaining: "below limit of detection" (no number reported)
Compound 4: no number reported, and the estimate cannot be compared.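

Compound 1 and compound 4 both come without a number, so no step can be read between them. As far as these compounds go, how far this change of atoms in the fused ring alters the compound remaining stays open. No evidence here bears on this result.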